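Dimethylamino in place of fluoro: compound 1 to compound 3

This account rests on a few compounds, and the source may have more. Where it says the series, first, only, none or still open, it means among the compounds named here.

Two compounds of the series have numbers in a functional assay on L1210 cells (Mus musculus) for cytotoxicity, with a stated time of 48 h; on this read-out lower numbers stand for stronger inhibition and higher numbers for weaker inhibition. Compound 1 `O=C1/C(=C/c2ccc(F)cc2)CCC/C1=C\c1ccc([N+](=O)[O-])cc1` gives 26800 nM, the higher of the two. Compound 2 `O=C1/C(=C/c2ccc(Cl)cc2)CCC/C1=C\c1ccccc1[N+](=O)[O-]` gives 9380 nM, a gap beyond the scatter; the two differ at more than one place, so only the values themselves are compared. Compound 3 `CN(C)c1ccc(/C=C2\CCC/C(=C\c3ccc([N+](=O)[O-])cc3)C2=O)cc1` is not yet measured. It differs from compound 1 by dimethylamino in place of fluoro on an aromatic carbon. For the measured compounds named here, no measured pair covers this change. A moderate downward step, beyond the scatter, is expected, estimated as a 2.7-fold lower number from compound 1 to compound 3 (0.43 log units; beyond the scatter). Compound 3 is expected at 10000 nM, within 3000 nM to 40000 nM.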

Compound 3, half-maximal inhibitory concentration: > 500000 nM
Compound 3: no number, only a limit; the forecaster's own chance of this, stated with the estimate: 5%; middle value at least 50-fold (1.69 log units) away from the limit.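

In this assay compound 3 gives > 500000 nM, which is a limit of the assay and not a number. Dimethylamino in place of fluoro on this aromatic carbon gives an at least 18-fold higher number from compound 1 to compound 3 (1.27 log units; beyond the scatter), showing a sensitivity to the group at this position that the values of compound 1 and compound 2, which differ at more than one place, could not show. The full size of the step stays unknown: the limit of > 500000 nM in this assay, at which 1 of the 3 values shown sits.

On these data alone, whether the step belongs to dimethylamino alone or also extends to a primary amine, methoxy or a longer chain on this carbon remains open. Also open, as far as these compounds go, is whether the same exchange has a similar effect alongside the nitro group placement of compound 2.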